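The compounds below may be only part of what the source reports. "The series", "measured", "known", "first", "only" and "open" are said of these compounds alone.

Compound 1 `Cn1cc(C2=C(c3nn(CCCn4cccc4)c4ncccc34)C(=O)NC2=O)c2ccccc21` was examined in a functional assay on KB cells (Homo sapiens) for antiproliferative activity, read by MTT assay, with a stated time of 48 h; a lower number here means a stronger inhibitor, a higher number a weaker inhibitor. In this assay compound 1 gives > 100000 nM, which is a limit of the assay rather than a number. Compound 2 `Cn1cc(C2=C(c3nn(CCCn4cccc4)c4ncccc34)C(=O)N(c3ccccc3)C2=O)c2ccccc21` differs from compound 1 by phenyl in place of hydrogen on an amide-type nitrogen in a ring. In this assay compound 2 gives > 100000 nM, again a limit of the assay. The step that the two limits leave unreadable from compound 1 to compound 2 therefore cannot be read, and all that the two measurements show is the limit of > 100000 nM in this assay, at which 2 of the 2 values shown sit. Compound 3 `Cn1cc(C2=C(c3nn(CCCO)c4ncccc34)C(=O)NC2=O)c2ccccc21` has not yet been measured; its change from compound 1 is hydroxy in place of 1H-pyrrol-1-yl on a saturated chain carbon, three bonds along the chain from an aromatic nitrogen. No measured step bears on this change, so no direction can be drawn from the numbers shown. Compound 3 is expected to give 150000 nM, within an estimated range of 50000 nM to 500000 nM. The expected step that the limit leaves unreadable from compound 1 to compound 3 is thus estimated as none beyond the scatter.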

Compound 3, half-maximal inhibitory concentration: > 100000 nM
Compound 3 ended at the assay's limit; the forecaster's own chance of this, stated with the estimate: 80%; the middle value is on the limit's open side.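

Compound 3, like compound 1, sits at a limit of this assay rather than at a number, so the step between them cannot be read: the limit of > 100000 nM in this assay, at which 3 of the 3 values shown sit. The compounds shown leave open how much either the hydroxy or the 1H-pyrrol-1-yl group contributes to activity, since no value here falls inside the measurable range.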